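The compounds below may be only part of what the source reports. "The series", "measured", "known", "first", "only" and "open" are said of these compounds alone.

In a functional assay on HL-60 cells (Homo sapiens) for inhibition, read by MTT assay, with a stated time of 72 h (on this read-out lower numbers stand for stronger inhibition and higher numbers for weaker inhibition), three compounds have been tested so far. Compound 1 `CCc1nc(-c2ccccc2F)c(C(=O)N2CCN(c3cccc(Cl)c3)CC2)o1` gives 139 nM in this assay, and compound 2 `COc1cc(OC)cc(N2CCN(C(=O)c3onc(C)c3-c3ccccc3F)CC2)c1` gives 165 nM; these two values lie within the usual scatter of each other. Compound 3 `C=C(C)c1ccc(N2CCN(C(=O)c3oc(C)nc3-c3ccccc3)CC2)cc1` gives "not active" (no number reported) in this assay, so no number stands for it: all that is known is that it fell short of the measurable inhibition shown by compound 1 and compound 2.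

Compound 4 `Cc1nc(-c2ccccc2)c(C(=O)N2CCN(c3ccccc3F)CC2)o1` has not yet been measured. It differs from compound 3 in a single place: 2-fluorophenyl in place of 4-(1-methylethenyl)phenyl on an amine nitrogen in a ring. Within the data shown here, since compound 3 gives no number, no step to compound 4 can be computed, and the size of the change cannot be put on a scale. What can be said is that the two compounds with numbers, compound 1 and compound 2, both carry a small substituted ring on the amine nitrogen of the shared core and both show measurable inhibition, while compound 3 does not; a step toward stronger inhibition in this assay is therefore expected, of unknown size.

Compound 4 is expected to give about 600 nM in this assay, with a range from 150 nM to 3000 nM, and with a real chance that it is again reported only as not active.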

Compound 4, half-maximal inhibitory concentration: 147 nM
Beside the measured number, compound 4's estimate is 4.1-fold (0.61 log units) above it; measured number below the stated range.
By their numbers in this assay, from the lowest: compounds 1, 4 and 2 (each within the scatter of the next).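

In this assay, among these compounds, compound 3 carries no number while compound 4 gives 147 nM and no step between the two can be read. No measurement shown offers an explanation for this result. Going by these compounds, what stays open is how much inhibition changes when 2-fluorophenyl replaces 4-(1-methylethenyl)phenyl on the ring nitrogen of compound 3.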